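A Single Nitro Group on a Weakly Active Core

This account rests on a few compounds, and the source may have more. Where it says the series, first, only, none or still open, it means among the compounds named here.

Three compounds share one core and differ in the side chain that hangs from it through a hydrazone. For compound 1 `COc1ccc(/C=C/C=N/N2C(=S)NC3C2N(C)C(=O)N3C)cc1` and compound 2 `CC(/C=N/N1C(=S)NC2C1N(C)C(=O)N2C)=C\c1ccccc1` no number exists. In an ADME assay on HEK293 cells (Homo sapiens) for inhibition, read by MTT assay, with a stated time of 72 h (on this read-out lower numbers stand for stronger inhibition and higher numbers for weaker inhibition), compound 1 gives "not determined" (no result reported), and in the same assay compound 2 gives "not determined" (no result reported), so they contribute nothing to a comparison. Compound 3 `CCN1C(=O)N(CC)C2C1NC(=S)N2/N=C/C=C/c1ccccc1` is thus the only reference point in this series, and in this assay compound 3 gives 42100 nM, which on this read-out is a weak inhibition. Compound 4 `CCN1C(=O)N(CC)C2C1NC(=S)N2/N=C/C=C/c1ccccc1[N+](=O)[O-]` is the next compound to be measured and differs from compound 3 in exactly one place: nitro in place of hydrogen on an aromatic carbon. Among the compounds with values here, no pair of measured compounds in this set shows what such an exchange does to the read-out, so nothing about its direction can be read from the data; the only firm fact is the weak inhibition of compound 3. Within the data shown here, with one reference value and no comparable step to lean on, the expected step from compound 3 to compound 4 a 1.1-fold lower number from compound 3 to compound 4 (0.04 log units; within the scatter) is none beyond the usual scatter of repeated measurements. On that basis compound 4 is expected to give about 38000 nM, with a plausible range from 12000 nM to 120000 nM.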

Compound 4, half-maximal inhibitory concentration: 19300 nM
The estimate for compound 4 lay 2.0-fold (0.29 log units) above the measured number, and the stated range covers the measured number.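

In this assay, the change from phenyl to 2-nitrophenyl gives a 2.2-fold lower number from compound 3 to compound 4 (0.34 log units; beyond the scatter), the first measured sign that this spot on the aromatic ring, ortho to a large group, can shift the read-out at all. The step is modest but beyond the usual scatter of repeated measurements, and it runs towards stronger inhibition, although compound 4 still needs 19300 nM to reach half-maximal inhibition and so remains far from a strong inhibitor. No measurement shown here accounts for the shift, so the data record the size and direction of this one exchange but not the reason for it.

A single pair cannot show whether the shift belongs to nitro specifically or whether other groups on the same carbon, such as an amine, a carboxylic acid or a fluorine atom, would move the number as far, further or the opposite way. On these data alone, it also remains open whether nitro would have the same effect on another carbon of this ring, or on the side chains of compound 1 and compound 2, which have no numbers to compare.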